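Replacing 4-hydroxy-2-methylphenyl with 4-ethylphenyl on a shared core

The source may report more compounds than this note shows. Statements on the series, on what has been measured and on what is new or still open speak of the compounds shown alone.

Compound 1 `Cc1ccc(C2=NN(c3ccc(S(C)(=O)=O)cc3)C(=O)CC2)cc1`: 6070 nM
Compound 2 `Cc1cc(O)ccc1C1=NN(c2ccc(S(C)(=O)=O)cc2)C(=O)CC1`: 74400 nM
Compound 3 `CCc1ccc(C2=NN(c3ccc(S(C)(=O)=O)cc3)C(=O)CC2)cc1`: not yet measured

In a functional assay on COLO 205 cells (Homo sapiens) for inhibition, read by sulforhodamine B assay, with a stated time of 48 h (a higher number here means a weaker inhibitor of growth, a lower number a stronger inhibitor of growth), compound 2, at 74400 nM, holds the higher of the two measured numbers, and so is the weaker inhibitor of the pair. The next step goes from compound 2 to compound 3: 4-ethylphenyl in place of 4-hydroxy-2-methylphenyl on a carbon with a double bond to nitrogen. In words, 4-ethylphenyl comes in place of 4-hydroxy-2-methylphenyl on a carbon with a double bond to nitrogen.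

Going by the values given here, only one measured step bears on this change. It is a 12-fold higher number from compound 1 to compound 2 (1.09 log units; beyond the scatter), a large step beyond the scatter, in which 4-hydroxy-2-methylphenyl replaced 4-methylphenyl. The change to compound 3 removes that same 4-hydroxy-2-methylphenyl, so a step of similar size in the opposite direction seems likely. The 4-ethylphenyl group itself has not been measured here, which leaves its difference from the 4-methylphenyl of compound 1 open and widens the range. An estimated step of an 11-fold lower number from compound 2 to compound 3 (1.06 log units; beyond the scatter) is therefore expected. For compound 3 the expected value is 6500 nM, with an estimated range of 2500 nM to 20000 nM.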

Compound 3, concentration for total growth inhibition: 12600 nM
Estimate against measurement, compound 3: 1.9-fold (0.29 log units) below; the range from low to high includes it.
By their numbers in this assay, from the lowest: compound 1; then compound 3; then compound 2.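

In this assay, going by these compounds alone, the step of a 2.1-fold higher number from compound 1 to compound 3 (0.32 log units; beyond the scatter) gives the first reading of a change to the chain on this aromatic ring: methyl in place of hydrogen on a saturated chain carbon bound to an aromatic carbon raises the number modestly, beyond the scatter, so 4-ethylphenyl and 4-methylphenyl are not interchangeable at this position. The step of a 5.9-fold lower number from compound 2 to compound 3 (0.77 log units; beyond the scatter) shows that 4-ethylphenyl, which has no hydrogen-bond donor or acceptor, gives a lower number than 4-hydroxy-2-methylphenyl, yet it does not return the number to that of compound 1, so the size of the exchange depends on the group that enters as well as the one that leaves. Nothing measured in this set accounts for either step.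

The compounds shown leave open whether the high number of compound 2 goes with the hydroxyl, with the added methyl or with the two together, since they change in a single step and neither 4-hydroxyphenyl nor 2-methylphenyl stands among them. They also leave open whether a longer chain, as in 4-propylphenyl, would raise the number further, as the single added methyl does here.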